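Thiocarbamate benzamide series: amine variation on the thiocarbonyl

The source may hold more compounds than are shown below. What is called first, only, known or untested is meant among the compounds shown, and "the series" means these compounds.

Measured so far:
- compound 1, `CN(C(=S)SCc1ccc(C(=O)Nc2ccccc2N)cc1)c1cccnc1`: 70.5%
- compound 2, `Nc1ccccc1NC(=O)c1ccc(CSC(=S)N2CCN(Cc3ccncc3)CC2)cc1`: 72.9%

Both numbers come from a functional assay on HeLa cells (Homo sapiens) for antiproliferative activity, read by CCK-8 assay, with a stated time of 72 h, tested at 8 uM; a lower number here means a weaker effect, a higher number a stronger effect of the compound at the concentration tested. Compound 1 gives 70.5% and compound 2 gives 72.9%; the gap between them lies within the usual scatter, so neither can be placed above the other. The two compounds share the same core and differ only in the amine attached to the thiocarbonyl carbon.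

Compound 3, `Nc1ccccc1NC(=O)c1ccc(CSC(=S)N2CCCC2)cc1`, is not yet measured in this assay. Relative to compound 1 the change is pyrrolidin-1-yl in place of methyl(pyridin-3-yl)amino on a thiocarbonyl carbon. Among the measured compounds shown here, no step between measured compounds is available for this exact change; the only guide is that compound 1 and compound 2, with two different amines in this position, give values within the scatter of each other.

The step of a number 2.5 percentage points lower from compound 1 to compound 3 (within the scatter) in this assay is therefore expected to be small, with no clear direction beyond the scatter. Compound 3 is expected to give about 68%, with a likely range from 55% to 80%.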

Compound 3, a percentage reported as inhibition, at one concentration (the size of the read-out at that concentration, not a potency): 77.8%
Compound 3: middle estimate off by 9.8 percentage points, on the low side, within the range that was stated.
By their numbers in this assay, from the lowest: compounds 1, 2 and 3 (each within the scatter of the next).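

In this assay, putting pyrrolidin-1-yl in place of methyl(pyridin-3-yl)amino on a thiocarbonyl carbon gives a number 7.3 percentage points higher from compound 1 to compound 3 (within the scatter) and so does not separate the two amines. This position therefore carries a five-membered non-aromatic ring with no hydrogen-bond acceptor as well as the six-membered aromatic ring of compound 1, with no change beyond the scatter at this single concentration. No measured property bears on this result.

Still open, as far as these compounds go, is whether the read-out holds with an open-chain amine such as diethylamino, or with a ring holding a second hetero atom such as morpholin-4-yl. Also open, from the compounds shown here alone, is whether full concentration-response curves would separate compounds that a single concentration cannot distinguish.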